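This account rests on a few compounds, and the source may have more. Where it says the series, first, only, none or still open, it means among the compounds named here.

Three compounds sharing one core were tested in a functional assay on U-87MG ATCC cells for antiproliferative activity against U-87 MG (Homo sapiens), read by MTT assay, with a stated time of 48 h, tested at 5 uM; a higher number here means a weaker effect of the compound at the concentration tested, a lower number a stronger effect. Compound 2 `Cc1nc(-c2ccccc2)sc1C(=O)CSc1nc(-c2cccc(Cl)c2)c(C#N)c(=O)[nH]1` gives 86.9%. Compound 1 `Cc1nc(-c2ccc(Cl)cc2)sc1C(=O)CSc1nc(-c2cccc(Cl)c2)c(C#N)c(=O)[nH]1` carries chloro in place of hydrogen on an aromatic carbon relative to compound 2; in this assay compound 1 gives 80.2%, the step being a number 6.7 percentage points lower from compound 2 to compound 1 (within the scatter). Compound 3 `Cc1nc(-c2ccccc2)sc1C(=O)CSc1nc(-c2ccc(Cl)cc2)c(C#N)c(=O)[nH]1` differs from compound 2 in the core by 4-chlorophenyl in place of 3-chlorophenyl on an aromatic carbon; in this assay compound 3 gives 90.9%, with the step of a number 4 percentage points higher from compound 2 to compound 3 (within the scatter). Compound 4 `Cc1nc(-c2ccc(Cl)cc2)sc1C(=O)CSc1nc(-c2ccc(Cl)cc2)c(C#N)c(=O)[nH]1` has not yet been measured; relative to compound 3 it carries chloro in place of hydrogen on an aromatic carbon, the same change that leads from compound 2 to compound 1, at a place described in identical words. The step into compound 4 is expected to be a number 6.9 percentage points lower from compound 3 to compound 4 (within the scatter), resting on the earlier step of a number 6.7 percentage points lower from compound 2 to compound 1 (within the scatter). Compound 4 is therefore estimated at 84%, expected to fall between 72% and 96%.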

Compound 4, a percentage reported as activity, at one concentration (the size of the read-out at that concentration, not a potency): 99%
For compound 4 the middle estimate is 15 percentage points below the measured one, and the stated range ends below it.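

Swapping hydrogen for chloro, which turns phenyl into 4-chlorophenyl, gives a step of a number 8.1 percentage points higher from compound 3 to compound 4 (within the scatter) in this assay, and this does not match the same change on the other core: the same change on two cores in this assay, a number 6.7 percentage points lower (within the scatter) from compound 2 to compound 1 and a number 8.1 percentage points higher (within the scatter) from compound 3 to compound 4, 14.8 percentage points apart, beyond the scatter of two such steps Putting 4-chlorophenyl in place of 3-chlorophenyl gives a step of a number 18.8 percentage points higher from compound 1 to compound 4 (beyond the scatter), which also differs from the earlier step for that change: the same change on two cores in this assay, a number 4 percentage points higher (within the scatter) from compound 2 to compound 3 and a number 18.8 percentage points higher (beyond the scatter) from compound 1 to compound 4, 14.8 percentage points apart, beyond the scatter of two such steps A step seen on one core therefore cannot simply be carried over to another in these four compounds, though the data do not show why the steps differ or whether this holds beyond them.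

Open, going by these compounds, is how an amine, a carboxylic acid or a longer chain would behave in place of chloro. Also open, on these data alone, is how these compounds compare at other concentrations.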